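The source may hold more compounds than are shown below. What is called first, only, known or untested is meant among the compounds shown, and "the series" means these compounds.

Measured compounds in a functional assay on MCF7 cells (Homo sapiens) for inhibition; on this read-out higher numbers stand for weaker inhibition and lower numbers for stronger inhibition:
Compound 1, `CCn1c(=O)/c(=C2\Sc3ccc(C)cc3N2C)s/c1=C\c1ccncc1Nc1ccccc1Cl`: compound 1 gives 650 nM.
Compound 2, `CCn1c(=O)/c(=C2\Sc3ccccc3N2C)s/c1=C\c1ccncc1Nc1ccccc1C`: compound 2 gives 990 nM.
Compound 3, `CCn1c(=O)/c(=C2\Sc3ccc(OC)cc3N2C)s/c1=C\c1ccncc1Nc1ccccc1C`: compound 3 gives 420 nM.

Compound 3 gives the lowest number of the three. Going by the values given here, its nearest neighbour is compound 1, whose number lies within the scatter of it, while compound 2 lies beyond the scatter, as the one directly measured step shows: a 2.4-fold lower number from compound 2 to compound 3 (0.37 log units; beyond the scatter).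

Compound 4, `CCn1c(=O)/c(=C2\Sc3ccc(OC)cc3N2C)s/c1=C\c1ccncc1Nc1ccccc1Cl`, has not yet been measured. It differs from compound 3 in one place: chloro in place of methyl on an aromatic carbon. Among the compounds with values here, none of the measured steps covers this exchange. Within the data shown here, the only hint comes from compound 1, which carries the chloro group on the same aromatic carbon and sits within the scatter of compound 3, though compound 1 differs from compound 3 in a second place as well. On that basis compound 4 is expected to stay close to compound 3, with the estimated step of no change at the digits printed from compound 3 to compound 4 (within the scatter) not reaching beyond the scatter. The estimate for compound 4 in this assay is therefore 420 nM, with a range from 200 nM to 850 nM.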

Compound 4, half-maximal inhibitory concentration: 710 nM
Compound 4: middle estimate off by 1.7-fold (0.23 log units), on the low side; measured number inside the range.
By their numbers in this assay, from the lowest: compounds 3, 1, 4 and 2 (each within the scatter of the next, the first and the last beyond it).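

Going by these compounds alone, this gives the first direct reading of the exchange of 2-methylphenyl for 2-chlorophenyl: in this assay, a 1.7-fold higher number from compound 3 to compound 4 (0.23 log units; within the scatter), so this aromatic carbon, ortho to a large group, accepts either group without a change beyond the scatter. With chloro held in place on that ring, the other exchange gives a 1.1-fold higher number from compound 1 to compound 4 (0.04 log units; within the scatter), which shows that methoxy and methyl on the core cannot be told apart here. No measurement shown bears on why these exchanges read as they do.

The compounds shown leave open how a carboxylic acid, an amine or a larger group such as trifluoromethyl would read on this same aromatic carbon. They also leave open whether the ethyl chain on the core could give way to a longer chain without a change in this read-out.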